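Cytotoxicity notes: aryl substituent changes on a shared core

The compounds below may be only part of what the source reports. "The series", "measured", "known", "first", "only" and "open" are said of these compounds alone.

Measured compounds:
- Compound 1, `COc1ccccc1-c1cc(C)c(Nc2ccnc(Nc3ccc(C#N)cc3)n2)c(C)c1`: 940 nM
- Compound 2, `Cc1cc(-c2ccccc2)cc(C)c1Nc1ccnc(Nc2ccc(C#N)cc2)n1`: 4170 nM
- Compound 3, `Cc1cc(-c2cccc(C#N)c2)cc(C)c1Nc1ccnc(Nc2ccc(C#N)cc2)n1`: 920 nM

In an ADME assay on MT4 cells (Homo sapiens) for cytotoxicity, read by MTT assay, with a stated time of 4 days (a higher number here means that more compound is tolerated, a lower number that less compound is tolerated), compound 3 gives the lowest of the three numbers, but its nearest neighbour is compound 1, and a 1.0-fold lower number from compound 1 to compound 3 (0.01 log units; within the scatter), so these two cannot be told apart. The only clear separation is to compound 2: a 4.5-fold lower number from compound 2 to compound 3 (0.66 log units; beyond the scatter). Compound 4, `Cc1cc(-c2cc(F)cc(F)c2)cc(C)c1Nc1ccnc(Nc2ccc(C#N)cc2)n1`, has not yet been measured. The change from compound 3 is 3,5-difluorophenyl in place of 3-cyanophenyl on an aromatic carbon.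

For the measured compounds named here, no measured step swaps the nitrile for fluorine, so the bearing steps are indirect. Removing the nitrile from the pendant ring, as the reverse of a 4.5-fold lower number from compound 2 to compound 3 (0.66 log units; beyond the scatter), would point to a higher number, while a 1.0-fold lower number from compound 1 to compound 3 (0.01 log units; within the scatter) shows that exchanging one substituted pendant ring for another can leave the number unchanged. Going by the values given here, the difluoro pattern has no precedent in this set. A modest rise in this assay is therefore expected for compound 4, a 2.2-fold higher number from compound 3 to compound 4 (0.34 log units; beyond the scatter), with wide uncertainty.

Compound 4 is estimated at 2000 nM, with a range from 800 nM to 5000 nM.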

Compound 4, half-maximal cytotoxic concentration: 3910 nM
Beside the measured number, compound 4's estimate is 2.0-fold (0.29 log units) below it, and the stated range covers the measured number.
By their numbers in this assay, from the lowest: compounds 3 and 1 (each within the scatter of the next); then compounds 4 and 2 (each within the scatter of the next).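

In this assay, compound 4 shows that a substituted pendant ring does not by itself bring the number down: a 1.1-fold lower number from compound 2 to compound 4 (0.03 log units; within the scatter), so the 3,5-difluorophenyl group cannot be told apart from plain phenyl at this position. The 3-cyanophenyl and 2-methoxyphenyl groups do separate from it, with a 4.3-fold higher number from compound 3 to compound 4 (0.63 log units; beyond the scatter) and a 4.2-fold higher number from compound 1 to compound 4 (0.62 log units; beyond the scatter), so the earlier link between substitution and a lower number holds for compounds 1 and 3, while compound 4 goes against it. No measurement given here explains this difference between the pendant rings.

On these data alone, it remains open whether the lower number is specific to the nitrile and methoxy groups or extends to other substituents. A pendant ring carrying an amine or a carboxylic acid would test how far that separation reaches.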